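This account rests on a few compounds, and the source may have more. Where it says the series, first, only, none or still open, it means among the compounds named here.

Measured so far in a physicochemical assay for lipophilicity, read by HPLC; on this read-out lower numbers stand for lower lipophilicity and higher numbers for higher lipophilicity:
- compound 1 `O=C1/C(=C/c2ccccc2)C(c2ccccc2)Oc2ccccc21`: 3.9
- compound 2 `Cc1ccc(/C=C2/C(=O)c3ccccc3OC2c2ccccc2)cc1`: 4.36

Compound 2 stands highest of the two numbers in this assay; its nearest neighbour is compound 1, the step being a number 0.46 log units higher from compound 1 to compound 2 (beyond the scatter). Compound 3 `O=C1/C(=C/c2ccc(Br)cc2)C(c2ccccc2)Oc2ccccc21` is the next compound to be measured in this assay. Its difference from compound 2 is bromo in place of methyl on an aromatic carbon.

Among the measured compounds shown here, only one measured step exists, and it concerns methyl in place of hydrogen on an aromatic carbon, a number 0.46 log units higher from compound 1 to compound 2 (beyond the scatter). For the measured compounds named here, no measured step exchanges methyl for bromo, so that step bears on the present change only as a sign that the position accepts a small group with a rise in this assay. A step for compound 3 of about a number 0.19 log units higher from compound 2 to compound 3 (within the scatter) is expected, a small rise that may not clear the scatter. Compound 3 is estimated at 4.55, with a range from 4.2 to 4.9.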

Compound 3, partition coefficient: 4.46
Estimate against measurement, compound 3: 0.09 log units above, and the stated range covers the measured number.
By their numbers in this assay, from the lowest: compound 1; then compounds 2 and 3 (each within the scatter of the next).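

In this assay, the exchange of 4-methylphenyl for 4-bromophenyl gives a number 0.10 log units higher from compound 2 to compound 3 (within the scatter) and so does not separate the two groups at this position. Bromo in place of hydrogen gives a number 0.56 log units higher from compound 1 to compound 3 (beyond the scatter) and, with the methyl step, makes two groups on this aromatic carbon that stand beyond the scatter from hydrogen in the same direction. No measured information bears on the origin of these steps.

From the compounds shown here alone, what an amine, a carboxylic acid or a longer chain such as butyl would give on this aromatic carbon in this assay stays open, so the two steps describe only methyl and bromo. Also open, going by these compounds, is whether bromo or methyl would give similar steps at another place on the shared core.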